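The compounds below may be only part of what the source reports. "The series", "measured", "known", "first", "only" and "open" are said of these compounds alone.

Measured compounds:
- compound 1, `CCOC(=O)c1nnn(-c2cccc(NC(=O)c3ccc(/C=C/C(=O)c4ccc(Cl)cc4)cc3)c2)c1C`: in an ADME assay on Vero cells (Chlorocebus sabaeus) for cytotoxicity, read by MTT assay, with a stated time of 72 h (a lower number here means that less compound is tolerated, a higher number that more compound is tolerated), compound 1 stands at "not determined" (no result reported).
- compound 2, `COC(=O)c1cc(-c2cccc(NC(=O)c3ccc(/C=C/C(=O)c4ccc(Cl)cc4)cc3)c2)on1`: in this assay compound 2 gives > 50 ug/mL, which is a limit of the assay and not a number.

Compound 2 therefore stands only at the limit of > 50 ug/mL in this assay, at which 1 of the 2 values shown sits, and no single figure for it is available; compound 1 adds nothing, since no result was reported for it in this assay. Nothing can be said about a step between the two measured compounds.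

Compound 3, `CCOC(=O)c1cc(-c2cccc(NC(=O)c3ccc(/C=C/C(=O)c4ccc(Cl)cc4)cc3)c2)on1`, is the unmeasured partner of compound 2. The change is methyl in place of hydrogen on a saturated chain carbon bound to an oxygen next to a carbonyl group, so that methoxycarbonyl becomes ethoxycarbonyl. Because compound 2 sits at the limit of > 50 ug/mL in this assay, at which 1 of the 2 values shown sits, the step from compound 2 to compound 3 in this assay is expected to be none beyond the scatter, and the estimate a step that the limit leaves unreadable from compound 2 to compound 3 reflects this. Compound 3 is accordingly expected to give about 55 ug/mL in this assay, within a range of 25 ug/mL to 110 ug/mL, most likely again reported only as a limit.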

Compound 3, half-maximal cytotoxic concentration: > 80 ug/mL
Compound 3 was reported as a limit; the forecaster's own chance of this, stated with the estimate: 75%; middle value at least 1.4-fold (0.16 log units) from the limit.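

The step from compound 2 to compound 3, methoxycarbonyl to ethoxycarbonyl, cannot be read in this assay: both compounds stand only at limits of the assay, and neither gives a single number. The compounds shown leave open where the half-maximal cytotoxic concentration of either compound lies, and whether this change shifts it at all.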